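Fluoro to methyl: from compound 3 to compound 4

The source may report more compounds than this note shows. Statements on the series, on what has been measured and on what is new or still open speak of the compounds shown alone.

Compound 3 (`Nc1ccc(-c2nc3ccccc3s2)cc1F`) is the reference point. In a functional assay on cells (Cancer cell lines, Homo sapiens) for inhibition (on this read-out higher numbers stand for weaker inhibition of growth and lower numbers for stronger inhibition of growth), compound 3 gives < 10 nM as a limit of the assay and not a number. Its standing in the series is therefore the limit of < 10 nM in this assay, at which 2 of the 3 values shown sit, and no exact potency can be read from it. Compound 2 (`Cc1cc(-c2nc3ccc(F)cc3s2)ccc1N`) gives < 10 nM in this assay as a limit of the assay too. Compound 1 (`Cc1cc(-c2nc3cccc(F)c3s2)ccc1N`) gives a true number in this assay with 40 nM as its read-out.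

Compound 4 (`Cc1cc(-c2nc3ccccc3s2)ccc1N`) has methyl in place of fluoro on an aromatic carbon ortho to an amino group. Compounds 1 and 2 already carry that methyl, but each also bears a fluoro that compound 4 lacks, so neither isolates this change. No step beyond the scatter is expected in this assay and no direction can be assigned. The expected change is a step that the limit leaves unreadable from compound 3 to compound 4 as an estimate only. Compound 1 at 40 nM keeps the upper end of the expected range open. For compound 4 the estimated value is 6 nM within an expected range from 1 nM to 30 nM and a report as a limit is quite likely.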

Compound 4, concentration for 50% growth inhibition: < 10 nM
Compound 4: a limit, no number; the forecaster's own chance of this, stated with the estimate: 65%; the middle value does not contradict the limit.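

Compound 4 gives < 10 nM in this assay, which is a limit of the assay and not a number. Among these compounds, its value makes the first readable step, the loss of a fluoro, an at least 4.0-fold lower number from compound 1 to compound 4 (0.60 log units; beyond the scatter), so the fluoro of compound 1 goes with weaker inhibition of growth on this methyl-bearing core, while compound 2, which also carries a fluoro, gives no readable step. The steps to compound 4 from compound 3 and from compound 2 cannot be read, and fluoro and methyl ortho to an amino group therefore cannot be ranked, because these values all stand at the same limit: the limit of < 10 nM in this assay, at which 3 of the 4 values shown sit.

Any true difference between fluoro and methyl at this place remains hidden in this assay, as does the real size of the gain from compound 1. Also open, as far as these compounds go, is whether a chloro, a methoxy or an ethyl ortho to an amino group would stay at the limit, or whether an acetamide in place of the amino group would keep the inhibition of growth.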